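The source may hold more compounds than are shown below. What is called first, only, known or untested is meant among the compounds shown, and "the series" means these compounds.

Compound 1 `O=C(Nc1cccc(-n2cc(-c3ccncc3)c(-c3ccc(Cl)c(O)c3)n2)c1)Nc1cccc(C(F)(F)F)c1` carries a urea linking two aromatic rings, one of them bearing the shared core and the other a trifluoromethyl group. In a functional assay on OVCAR-5 cells (Homo sapiens) for inhibition, read by sulforhodamine B assay, with a stated time of 48 h (a higher number here means a weaker inhibitor of growth, a lower number a stronger inhibitor of growth), compound 1 gives > 32500 nM, which is a limit of the assay rather than a number. Compound 2 `O=C(Nc1cccc(-n2cc(-c3ccncc3)c(-c3ccc(Cl)c(O)c3)n2)c1)Nc1ccc(Cl)c(Cl)c1` replaces the trifluoromethyl-bearing ring with a 3,4-dichlorophenyl on the same urea nitrogen. In this assay compound 2 gives > 32500 nM, again a limit. Among the compounds with values here, the step from compound 1 to compound 2 is therefore a step that the two limits leave unreadable from compound 1 to compound 2, and the only evidence on the shared numbers is the limit of > 32500 nM in this assay, at which 2 of the 2 values shown sit.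

Compound 3 `O=C(Nc1cccc(-n2cc(-c3ccncc3)c(-c3ccc(Cl)c(O)c3)n2)c1)Nc1cc(C(F)(F)F)cc(C(F)(F)F)c1` differs from compound 1 by trifluoromethyl in place of hydrogen on an aromatic carbon, that is, a second trifluoromethyl added to the ring that already holds one. Within the data shown here, the one measured step that bears on changes at this ring gives no readable size, so nothing beyond the scatter can be expected in either direction from it. On that basis the estimate for compound 3 is 40000 nM, with a range from 15000 nM to 120000 nM, and the step from compound 1 to compound 3 is expected to be a step that the limit leaves unreadable from compound 1 to compound 3.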

Compound 3, concentration for total growth inhibition: 2030 nM
Compound 3: the middle estimate sits 20-fold (1.29 log units) above what was measured; measured number outside the range, below it.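

Adding a second trifluoromethyl to this ring gives an at least 16-fold lower number from compound 1 to compound 3 (1.20 log units; beyond the scatter) in this assay. Within the data shown here, the earlier step between compound 1 and compound 2 cannot be read, so this is the first change on this ring of the urea with a readable size, and it shows that an aromatic carbon meta to a trifluoromethyl group is a place where a substitution can make a large difference to the read-out. Among these compounds, compound 3 is also the only compound here with a true number rather than a limit, so it gives the series its first measured point on which later changes can be judged, while the rest stays at the limit: the limit of > 32500 nM in this assay, at which 2 of the 3 values shown sit.

The data do not tell whether this gain is specific to trifluoromethyl or would also come with another group at the same carbon, such as a methoxy group, an amine or a single chlorine. They also leave open why the change has this effect, and whether a similar addition to the 3,4-dichlorophenyl ring of compound 2 would lift that compound off its limit in the same way.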